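The compounds below may be only part of what the source reports. "The series", "measured", "known", "first", "only" and "open" are said of these compounds alone.

Measured so far:

Compound 1, `O=C(CN1CCN(c2ccc([N+](=O)[O-])cc2)CC1)C(O)(c1ccccc1)C1CCC1`: in a functional assay on ileum for antagonist activity at muscarinic acetylcholine receptor M3 (Cavia porcellus) (on this read-out lower numbers stand for stronger inhibition and higher numbers for weaker inhibition), compound 1 gives only a limit, > 10000 nM.

Compound 2, `O=C(CN1CCN(CC(=O)C(O)(c2ccccc2)C2CCC2)CC1)N1CCCC1`: in this assay compound 2 gives 210 nM.

Compound 3, `CC(C)=CCN1CCN(CC(=O)C(O)(c2ccccc2)C2CCC2)CC1`: in this assay compound 3 gives 22 nM.

Among the two actual numbers, compound 3 stands lowest; its nearest neighbour is compound 2, and the change a 9.5-fold lower number from compound 2 to compound 3 (0.98 log units; beyond the scatter) lies beyond the scatter. Compound 1 sits at the limit of > 10000 nM in this assay, at which 1 of the 3 values shown sits, and its steps to the others, an at least 47-fold lower number from compound 1 to compound 2 (1.67 log units; beyond the scatter) and an at least 450-fold lower number from compound 1 to compound 3 (2.65 log units; beyond the scatter), are both large.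

Compound 4, `O=C(CN1CCN(Cc2ccco2)CC1)C(O)(c1ccccc1)C1CCC1`, is not yet measured. It differs from compound 3 in one place: furan-2-yl in place of 2-methylprop-1-en-1-yl on a saturated chain carbon bound to an amine nitrogen in a ring. The step that bears most directly on it is a 9.5-fold lower number from compound 2 to compound 3 (0.98 log units; beyond the scatter), which altered the same carbon and was modest; the two steps from compound 1 concern the ring nitrogen one bond closer in. Neither furan-2-yl nor any aromatic group at this carbon has been tried, so the nearest guide is the small neutral 2-methylprop-1-en-1-yl of compound 3 itself. The step of a 1.8-fold higher number from compound 3 to compound 4 (0.26 log units; within the scatter) is expected to be small. Compound 4 is therefore estimated at 40 nM, between 10 nM and 160 nM.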

Compound 4, antagonist equilibrium constant: 750 nM
For compound 4 the middle estimate is 19-fold (1.27 log units) below the measured one; the measured number lies above the stated range.
By their numbers in this assay, from the lowest: compound 3; then compound 2; then compound 4. At a limit, above all of these: compound 1.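

In this assay, the only aromatic group shown at this saturated chain carbon bound to an amine nitrogen in a ring brings a large loss, a 34-fold higher number from compound 3 to compound 4 (1.53 log units; beyond the scatter), so furan-2-yl does not stand in for 2-methylprop-1-en-1-yl here. It also falls behind (pyrrolidin-1-yl)carbonyl, with a 3.6-fold higher number from compound 2 to compound 4 (0.55 log units; beyond the scatter), so furan-2-yl gives the highest number of the three groups at this carbon. Even so, (furan-2-yl)methyl on the amine nitrogen in a ring does far better than 4-nitrophenyl, with an at least 13-fold lower number from compound 1 to compound 4 (1.12 log units; beyond the scatter), a step that rests on a limit for compound 1: the limit of > 10000 nM in this assay, at which 1 of the 4 values shown sits.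

Going by these compounds, with a single aromatic example, it remains open whether the loss belongs to the furan oxygen or to aromatic rings at this carbon in general. A phenyl, a thiophen-2-yl or a saturated tetrahydrofuran-2-yl group at this carbon would separate these readings.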